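Side-chain swap at the same position: methylsulfanyl to carbamoyl

This account rests on a few compounds, and the source may have more. Where it says the series, first, only, none or still open, it means among the compounds named here.

Of the compounds shown here, three sharing one core have been measured in a functional assay on the whole organism (Tail, strain ICR) with Mus musculus as the target, in the tail flick test, with a stated time of 150 min, at a dose of 25 umol/kg by the oral route; a lower number here means a weaker effect, a higher number a stronger effect of the compound at the dose given. Compound 1 `N=C(N)NCCC[C@H](NC(=O)CN(c1nc(Cl)nc2[nH]cnc12)C1CC1)C(=O)O` gives 7.19% in this assay. Compound 2 `NCCCC[C@H](NC(=O)CN(c1nc(Cl)nc2[nH]cnc12)C1CC1)C(=O)O` gives 11.6% in this assay. Compound 3 `CSCC[C@H](NC(=O)CN(c1nc(Cl)nc2[nH]cnc12)C1CC1)C(=O)O` gives 4.14% in this assay, the smallest of the three numbers, though its separation from either neighbour is within the scatter: a number 3.1 percentage points lower from compound 1 to compound 3 (within the scatter) and a number 7.5 percentage points lower from compound 2 to compound 3 (within the scatter). The remaining pair is no different in kind: a number 4.4 percentage points higher from compound 1 to compound 2 (within the scatter).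

Compound 4 `NC(=O)CC[C@H](NC(=O)CN(c1nc(Cl)nc2[nH]cnc12)C1CC1)C(=O)O` has not yet been measured in this assay. Relative to compound 3 the change is carbamoyl in place of methylsulfanyl on a saturated chain carbon, three bonds along the chain from an amide-type nitrogen and a carbonyl carbon.

The measured steps that bear on this change are the two that exchange the group at the same place on the saturated chain carbon, a number 3.1 percentage points lower from compound 1 to compound 3 (within the scatter) and a number 7.5 percentage points lower from compound 2 to compound 3 (within the scatter); both are within the scatter, as is the third step between compound 1 and compound 2. Nothing among the three compounds shows that a change at this position moves the number beyond the scatter, so no step beyond the scatter is expected here: a number 1.9 percentage points higher from compound 3 to compound 4 (within the scatter) is the expected step. For compound 4 the estimate in this assay is 6%, with a range from 0% to 15%.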

Compound 4, a percentage reported as activity, at one dose (the size of the read-out at that dose, not a potency): 11.4%
For compound 4 the middle estimate is 5.4 percentage points below the measured one, and the stated range covers the measured number.
By their numbers in this assay, from the lowest: compounds 3, 1, 4 and 2 (each within the scatter of the next).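

In this assay carbamoyl is a fourth side chain at this saturated chain carbon, and its exchange for methylsulfanyl, which counts no hydrogen-bond donor, stays inside the usual spread (a number 7.3 percentage points higher from compound 3 to compound 4 (within the scatter)). The comparisons with the two basic-named earlier side chains read the same way (a number 0.2 percentage points lower from compound 2 to compound 4 (within the scatter); a number 4.2 percentage points higher from compound 1 to compound 4 (within the scatter)), so all four compounds now lie within the scatter of one another, and no exchange shown at this position separates any pair. No independent measurement is available to account for the differences among these numbers.

Open, on these data alone, is whether any group at this place can move the number beyond the scatter, for example a carboxylic acid in place of carbamoyl, a longer chain carrying the carbamoyl, or a phenyl ring on the chain. Also open, as far as these compounds go, is whether these four side chains would separate at another dose or time, since each number here is the size of the read-out under a single condition and not a potency.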